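The compounds below may be only part of what the source reports. "The series", "measured", "known", "first", "only" and "open" are said of these compounds alone.

Measured in a functional assay on CCRF-CEM cells (Homo sapiens) for inhibition; a higher number here means a weaker inhibitor, a lower number a stronger inhibitor:
Compound 1 `C#CCN(Cc1ccc2nc(C)nc(O)c2c1)c1ccccc1`: > 10700 nM, a limit
Compound 2 `C#CCN(Cc1ccc2nc(C)nc(O)c2c1)c1ccc(S(N)(=O)=O)cc1`: > 26000 nM, a limit
Compound 3 `C#CCN(Cc1ccc2nc(C)nc(O)c2c1)c1ccc(S(=O)(=O)N2CCN(C)CC2)cc1`: not yet measured

Compound 2 stands only at a limit, > 26000 nM, so no number is known for it in this assay. Compound 1 also gives only a limit, > 10700 nM. The next change leads to compound 3: 4-methylpiperazin-1-yl in place of amino on a sulfonyl sulfur. Among the measured compounds shown here, the only measured step with a bearing on it is a step that the two limits leave unreadable from compound 1 to compound 2, made by sulfamoyl in place of hydrogen on an aromatic carbon. That step sets neither a size nor a direction for the new change, so no step beyond the scatter is expected in this assay. The expected move is a step that the limit leaves unreadable from compound 2 to compound 3. For compound 3 the estimate is 30000 nM, with an expected range of 8000 nM to 100000 nM.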

Compound 3, half-maximal inhibitory concentration: > 10000 nM
Compound 3 gave a limit, no number (the forecaster's own chance of this, stated with the estimate: 65%); the middle value lies beyond the limit too.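

In this assay compound 3 gives > 10000 nM, which is a limit. Compound 1 and compound 2 also stand only at limits, so no step among these three compounds can be read. The compounds shown leave open how strongly any of them inhibits, and whether either sulfonyl group changes that.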